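Three Limits and a Nitrophenyl Replacement

The source may hold more compounds than are shown below. What is called first, only, known or untested is meant among the compounds shown, and "the series" means these compounds.

The three measured compounds share one core and differ only in the aryl group on the carbonyl carbon. Compound 1 `CCCOc1ccc(C(=O)/C=C/c2ccc(C(=O)Nc3cccc(-c4cc(C(=O)OC)no4)c3)cc2)cc1` carries a 4-propoxyphenyl group there. In an ADME assay on Vero cells (Chlorocebus sabaeus) for cytotoxicity, read by MTT assay, with a stated time of 72 h (a lower number here means that less compound is tolerated, a higher number that more compound is tolerated), compound 1 gives only a limit, > 40 ug/mL. Compound 2 `COC(=O)c1cc(-c2cccc(NC(=O)c3ccc(/C=C/C(=O)c4ccc(C)cc4)cc3)c2)on1` carries a 4-methylphenyl group. In this assay compound 2 likewise reaches only a limit, > 80 ug/mL. Compound 3 `COC(=O)c1cc(-c2cccc(NC(=O)c3ccc(/C=C/C(=O)c4ccccc4C)cc3)c2)on1` carries a 2-methylphenyl group. In this assay compound 3 also stands at a limit, > 25 ug/mL. Since all three values are limits, the steps a step that the two limits leave unreadable from compound 1 to compound 2, a step that the two limits leave unreadable from compound 1 to compound 3 and a step that the two limits leave unreadable from compound 2 to compound 3 cannot be read in size. Compound 3 thus stands at one of three limits, (the limit of > 25 ug/mL in this assay, at which 1 of the 3 values shown sits), the limit of > 40 ug/mL in this assay, at which 1 of the 3 values shown sits, and (the limit of > 80 ug/mL in this assay, at which 1 of the 3 values shown sits), with nothing showing whether it is tolerated more or less than the others.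

Compound 4 `COC(=O)c1cc(-c2cccc(NC(=O)c3ccc(/C=C/C(=O)c4cccc([N+](=O)[O-])c4)cc3)c2)on1` differs from compound 3 by 3-nitrophenyl in place of 2-methylphenyl on a carbonyl carbon. Within the data shown here, no measured step bears on this change with a readable size, so no shift beyond the scatter is expected. Compound 4 is expected to give about 40 ug/mL in this assay. For compound 4 the expected range runs from 15 ug/mL to 100 ug/mL, quite possibly again as a limit. The expected step is a step that the limit leaves unreadable from compound 3 to compound 4, nothing beyond the scatter.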

Compound 4, half-maximal cytotoxic concentration: > 40 ug/mL
Compound 4: no number, only a limit; the forecaster's own chance of this, stated with the estimate: 70%; the middle value sits exactly at the limit.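

In this assay compound 4 gives > 40 ug/mL, again only a limit. The steps from compound 1, compound 2 and compound 3 to compound 4 cannot be read in size. The compounds shown leave open the actual half-maximal cytotoxic concentration of all four, and whether the aryl group on the carbonyl carbon changes tolerance at all.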